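The compounds below may be only part of what the source reports. "The series", "measured", "known", "first", "only" and "open" are said of these compounds alone.

Compound 1, `Cc1ccc2nc(Cl)c(/C=C/C(=O)c3ccc(I)s3)cc2c1`: 129 nM
Compound 2, `Cc1cccc2cc(/C=C/C(=O)c3ccc(Br)s3)c(Cl)nc12`: 243 nM

Of the compounds shown here, two have been measured in a functional assay on HUVEC cells (Homo sapiens), read by BrdU incorporation, with a stated time of 72 h; a lower number here means a stronger inhibitor, a higher number a weaker inhibitor. Compound 1 shows the lowest of the two numbers, but compound 2 lies within the usual scatter of it, so the two are not separated in this assay. Compound 3, `Cc1csc(C(=O)/C=C/c2cc3cc(C)ccc3nc2Cl)c1`, has not yet been measured. It differs from compound 1 in one place: 4-methylthiophen-2-yl in place of 5-iodothiophen-2-yl on a carbonyl carbon. Among the compounds with values here, no measured pair in this set shows what such a change does, so the expectation rests on the two numbers alone. Since neither measured compound carries the entering group, a moderate step toward a higher number in this assay is expected, likely close to the edge of the scatter rather than far beyond it. The estimate for compound 3 is 300 nM, with a range from 100 nM to 900 nM. The expected step of a 2.3-fold higher number from compound 1 to compound 3 (0.37 log units; beyond the scatter) is taken to be modest.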

Compound 3, half-maximal inhibitory concentration: 106 nM
Estimate against measurement, compound 3: 2.8-fold (0.45 log units) above; measured number inside the range.
By their numbers in this assay, from the lowest: compounds 3, 1 and 2 (each within the scatter of the next, the first and the last beyond it).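

In this assay putting 4-methylthiophen-2-yl in place of 5-iodothiophen-2-yl on a carbonyl carbon gives a 1.2-fold lower number from compound 1 to compound 3 (0.09 log units; within the scatter) and so leaves compound 1 and compound 3 unseparated. This place in the molecule therefore tolerates losing the iodine when a methyl-bearing thiophene takes over, and the iodine is not required for a number of this size on the core of compound 1. Nothing measured here explains why the two compounds fall so close together. On these data alone, both groups are thiophenes with the same count of heavy atoms, so it remains open whether the thiophene itself matters or whether a phenyl ring or a furan would serve equally well on this carbonyl carbon. As far as these compounds go, it is also open whether a thiophene carrying an amine or a carboxylic acid would stay within the scatter of compound 3.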